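The compounds below may be only part of what the source reports. "The series", "measured", "known", "first", "only" and "open" are said of these compounds alone.

Measured compounds:
compound 1 `CN(C(=O)NC(=O)c1c(F)cccc1F)c1nc(C(F)(F)F)c(C(=O)N/N=C/c2cccc(C(F)(F)F)c2)s1`: 27.9 ug/mL
compound 2 `CN(C(=O)NC(=O)c1cccc(C(F)(F)F)c1)c1nc(C(F)(F)F)c(C(=O)N/N=C/c2cc(C(F)(F)F)cc(C(F)(F)F)c2)s1`: 5.38 ug/mL

Of the compounds shown here, two have been measured in a functional assay on HepG2 cells (Homo sapiens) for inhibition, read by MTT assay, with a stated time of 72 h; a higher number here means a weaker inhibitor, a lower number a stronger inhibitor. Compound 1 gives 27.9 ug/mL in this assay, and compound 2 gives 5.38 ug/mL. Compound 2 therefore stands with the lower of the two numbers, and the gap between compound 1 and compound 2 lies beyond the usual scatter. For the measured compounds named here, the two compounds differ in two places at once, so no single structural step between them can be read from these values.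

Compound 3 `CN(C(=O)NC(=O)c1c(F)cccc1F)c1nc(C(F)(F)F)c(C(=O)N/N=C/c2cc(C(F)(F)F)cc(C(F)(F)F)c2)s1` has not yet been measured. It differs from compound 2 in one place: 2,6-difluorophenyl in place of 3-(trifluoromethyl)phenyl on a carbonyl carbon. The rest of the shared core, including the hydrazone carrying the bis(trifluoromethyl)phenyl group of compound 2, is kept. Going by the values given here, the acyl group entering in compound 3 is the one already present in compound 1, whose value in this assay is higher than that of compound 2, but compound 1 also carries a different hydrazone, so that comparison does not isolate the change.

The step of a 1.9-fold higher number from compound 2 to compound 3 (0.27 log units; within the scatter) is expected to be a modest weakening, possibly not beyond the scatter. Compound 3 is estimated at 10 ug/mL in this assay, within a range from 4 ug/mL to 25 ug/mL.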

Compound 3, half-maximal inhibitory concentration: 6.28 ug/mL
Compound 3: middle estimate off by 1.6-fold (0.20 log units), on the high side, and the stated range covers the measured number.
By their numbers in this assay, from the lowest: compounds 2 and 3 (each within the scatter of the next); then compound 1.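

At the carbonyl carbon, 3-(trifluoromethyl)phenyl and 2,6-difluorophenyl cannot be told apart in this assay, since the exchange gives a 1.2-fold higher number from compound 2 to compound 3 (0.07 log units; within the scatter). With the acyl group held constant, trifluoromethyl in place of hydrogen on an aromatic carbon gives a 4.4-fold lower number from compound 1 to compound 3 (0.65 log units; beyond the scatter), so among these three compounds the large gap first seen between compound 1 and compound 2, which could not be assigned to either of its two changes, goes with the hydrazone side rather than the acyl side. Nothing available here accounts for either step.

As far as these compounds go, both acyl groups seen so far are phenyl groups carrying fluorine, so it remains open whether the same flat result at the carbonyl carbon would hold for a simple alkyl chain, or for a phenyl group bearing an amine or a carboxylic acid. It is also open whether the two acyl groups would still match when paired with the hydrazone of compound 1, since the compounds shown offer only one acyl group on that hydrazone.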